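Pyrrolidine nitrogen substituent: amide gives way to benzyl

The source may report more compounds than this note shows. Statements on the series, on what has been measured and on what is new or still open speak of the compounds shown alone.

Three compounds share one core and differ only in the group on the pyrrolidine nitrogen. Compound 1 `CC(C)(C)OC(=O)N1CCC[C@@H]1C(=O)N1CCC(NS(=O)(=O)c2cc(S(=O)(=O)c3ccccc3)ccc2C(F)(F)F)CC1` gives 210 nM in a functional assay on U2OS cells for antagonist activity at proto-oncogene Wnt-3 (Homo sapiens), read by a luciferase reporter, with a stated time of 18 h; a higher number here means that more compound is needed for the effect, a lower number that less compound is needed. Compound 2 `CC(C)(C)OC(=O)N1C(=O)CC[C@H]1C(=O)N1CCC(NS(=O)(=O)c2cc(S(=O)(=O)c3ccccc3)ccc2C(F)(F)F)CC1` gives 90 nM in this assay, and compound 3 `CC(C)(C)CC(=O)N1CCC[C@H]1C(=O)N1CCC(NS(=O)(=O)c2cc(S(=O)(=O)c3ccccc3)ccc2C(F)(F)F)CC1` gives 120 nM in this assay. Compound 3 stands second highest of the three numbers, within the scatter of both compound 2 and compound 1. Going by the values given here, the one single-point step so far, 1-(neopentylcarbonyl)pyrrolidin-2-yl in place of 1-(tert-butoxycarbonyl)pyrrolidin-2-yl, runs a 1.8-fold lower number from compound 1 to compound 3 (0.24 log units; within the scatter).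

Compound 4 `O=C([C@@H]1CCCN1Cc1ccccc1)N1CCC(NS(=O)(=O)c2cc(S(=O)(=O)c3ccccc3)ccc2C(F)(F)F)CC1` is not yet measured. It differs from compound 3 in one place: benzyl in place of neopentylcarbonyl on an amine nitrogen in a ring. Among the compounds with values here, the only step that bears on it, from compound 1 to compound 3, stayed within the scatter, but that step kept a carbonyl on the nitrogen, whereas here the neopentylcarbonyl leaves outright and benzyl enters. Within the data shown here, no measured pair covers this, so the direction is open. The expectation for compound 4 is a number near compound 3, estimated at 250 nM with a range of 80 nM to 800 nM, which means an expected step of a 2.1-fold higher number from compound 3 to compound 4 (0.32 log units; beyond the scatter).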

Compound 4, half-maximal effective concentration: 720 nM
Compound 4: middle estimate off by 2.9-fold (0.46 log units), on the low side; the range from low to high includes it.
By their numbers in this assay, from the lowest: compounds 2, 3 and 1 (each within the scatter of the next, the first and the last beyond it); then compound 4.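

In this assay, benzyl in place of neopentylcarbonyl on the amine nitrogen in the ring gives a 6.0-fold higher number from compound 3 to compound 4 (0.78 log units; beyond the scatter), and 1-benzylpyrrolidin-2-yl in place of 1-(tert-butoxycarbonyl)pyrrolidin-2-yl gives a 3.4-fold higher number from compound 1 to compound 4 (0.54 log units; beyond the scatter). The earlier single step at this nitrogen kept a carbonyl there and stayed within the scatter, whereas both steps that remove the carbonyl and bring in benzyl lie beyond it, so the position does respond to the choice of group. Nothing at hand gives a reason for this shift.

Loss of the carbonyl and entry of the aromatic ring arrive together in compound 4, so their shares cannot be separated. A benzoyl group, which holds both, and a neopentyl group, which holds neither, would divide the change between them.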